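A few compounds are considered here, and "the series" means these few. Any claim that something is new, unique, unknown or untested is made for them only; others in the source may bear on it.

In a functional assay on CCRF-CEM cells (Homo sapiens) (on this read-out higher numbers stand for an effect only at larger amounts of compound and lower numbers for an effect already at smaller amounts), compound 1 `Cc1nn(C[C@@H]2CO[C@H](CO)O2)c(=O)[nH]c1=O` gives > 100000 nM. That value is a limit of the assay and not a number, so compound 1 has no exact position on this scale. Compound 2 `Nc1ncn(C[C@H]2CO[C@@H](CO)O2)c(=O)n1` gives 80000 nM, and compound 3 `Nc1ncn(C[C@@H]2CO[C@@H](CO)O2)c(=O)n1` gives 70000 nM.

Compound 4 `Cc1nn(C[C@@H]2CO[C@@H](CO)O2)c(=O)[nH]c1=O` is the stereoisomer of compound 1 still to be measured, and the change is the two compounds have the same atoms and bonds and differ only in configuration as drawn: 1 of 2 stereo elements differ; a stereocentre at a saturated ring carbon is drawn S in compound 1 and R in compound 4. Nothing leaves and nothing enters. Going by the values given here, only one measured step bears on this kind of change, and it rests on (the fact that compounds 2 and 3 differ only in the configuration as drawn). That step is a 1.1-fold lower number from compound 2 to compound 3 (0.06 log units; within the scatter), which also involves a stereocentre at a saturated ring carbon drawn S in the first compound and R in the second.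

This single step is thin ground, and the starting point for compound 4 is only a limit. Even so, no shift beyond the scatter is expected in this assay because a 1.1-fold lower number from compound 2 to compound 3 (0.06 log units; within the scatter) shows none, and no direction is favoured. The expected step is a number no higher from compound 1 to compound 4 (the limit leaves the size open), a size taken to lie within the scatter. For compound 4 the estimate is 100000 nM, with an expected range from 50000 nM to 200000 nM. A report as a limit is also expected to be the more likely outcome.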

Compound 4, half-maximal effective concentration: > 100000 nM
Compound 4 was reported as a limit; the forecaster's own chance of this, stated with the estimate: 70%; the middle value sits exactly at the limit.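

In this assay compound 4 gives > 100000 nM, which is a limit of the assay and not a number. Compound 1 gives > 100000 nM, also a limit, so no step can be read from compound 1 to compound 4. The compounds shown leave open where either compound stands on this scale and whether the configuration at the saturated ring carbon matters for this pair.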